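A few compounds are considered here, and "the series" means these few. Any claim that something is new, unique, unknown or untested is made for them only; others in the source may bear on it.

Measured so far:
compound 1 `Cc1ccc(CN2c3ccccc3C(=O)N(Cc3ccccc3)S2(=O)=O)cc1` — 63000 nM
compound 2 `O=C1c2ccccc2N(Cc2ccc(Cl)cc2)S(=O)(=O)N1Cc1ccc(Cl)cc1` — 56000 nM

In a functional assay on MRC5 cells (Homo sapiens) (a higher number here means that more compound is tolerated, a lower number that less compound is tolerated), compound 1 gives 63000 nM. In this assay compound 2 gives 56000 nM. Compound 1 holds the higher of the two numbers, but its gap to compound 2 lies within the scatter, so the two cannot be ordered. Among the compounds with values here, no step between measured compounds that differ in one place is available, so there is no measured change in the read-out to lean on.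

Compound 3 `O=C1c2ccccc2N(Cc2cccc3ccccc23)S(=O)(=O)N1Cc1ccccc1` is not yet measured. It differs from compound 1 in one place: naphthalen-1-yl in place of 4-methylphenyl on a saturated chain carbon bound to a sulfonamide nitrogen in a ring. Within the data shown here, with only two measured compounds, close to each other, the working assumption is that the shared core sets the tolerated level and that the group on the saturated chain carbon bound to a sulfonamide nitrogen in a ring moves it little. A small step in this assay toward a lower number is expected, not clearly beyond the scatter. Compound 3 is expected to give 40000 nM in this assay, with a range from 15000 nM to 100000 nM. That estimate means an expected step of a 1.6-fold lower number from compound 1 to compound 3 (0.20 log units; within the scatter).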

Compound 3, half-maximal cytotoxic concentration: > 58000 nM
Compound 3 ended at the assay's limit (the forecaster's own chance of this, stated with the estimate: 15%); at least 1.4-fold (0.16 log units) between middle value and limit.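

In this assay compound 3 gives > 58000 nM, which is a limit of the assay and not a number, so the step from compound 1 to compound 3 cannot be read. The compounds shown leave open whether naphthalen-1-yl in place of 4-methylphenyl on a saturated chain carbon bound to a sulfonamide nitrogen in a ring changes the tolerated level at all.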